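The source may report more compounds than this note shows. Statements on the series, on what has been measured and on what is new or still open speak of the compounds shown alone.

Compound 1 `Cc1cc(/C=C/C#N)cc(C)c1Oc1nc(Nc2ccc(N3CCN(S(N)(=O)=O)CC3)cc2)nc2sccc12` carries a 4-sulfamoylpiperazin-1-yl group on the shared core. In an ADME assay on MT4 cells (Homo sapiens) for cytotoxicity, read by MTT assay, with a stated time of 5 days (on this read-out lower numbers stand for higher toxicity in this test and higher numbers for lower toxicity in this test), compound 1 gives > 222000 nM, which is a limit of the assay rather than a number. Compound 2 `Cc1cc(/C=C/C#N)cc(C)c1Oc1nc(Nc2ccc(N3CCCC(NS(C)(=O)=O)C3)cc2)nc2ccsc12` bears a differently oriented core together with a 3-(methanesulfonamido)piperidin-1-yl group. In this assay compound 2 gives > 217000 nM, again a limit. Among the measured compounds shown here, compound 3 `Cc1cc(/C=C/C#N)cc(C)c1Oc1nc(Nc2ccc(CN3CCN(S(C)(=O)=O)CC3)cc2)nc2ccsc12` is the only member with a numerical result: in this assay compound 3 gives 20700 nM. For the measured compounds named here, the single measured step, an at least 10-fold lower number from compound 2 to compound 3 (1.02 log units; beyond the scatter), concerns the ring change and not the change at hand.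

Compound 4 `Cc1cc(/C=C/C#N)cc(C)c1Oc1nc(Nc2ccc(N3CCCC(NS(C)(=O)=O)C3)cc2)nc2sccc12` differs from compound 1 as follows: 3-(methanesulfonamido)piperidin-1-yl in place of 4-sulfamoylpiperazin-1-yl on an aromatic carbon. Going by the values given here, no measured step covers this exact change. What the data show is that the same incoming group, in compound 2, sits at the limit (the limit of > 217000 nM in this assay, at which 1 of the 3 values shown sits), and compound 1 sits at the limit (the limit of > 222000 nM in this assay, at which 1 of the 3 values shown sits). An expectation resting on these two limits is therefore a step of no size beyond the scatter, a number no higher from compound 1 to compound 4 (the limit leaves the size open), with compound 4 most likely reported as a limit once more. On this basis compound 4 is expected to give about 222000 nM in this assay, within a range from 100000 nM to 300000 nM.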

Compound 4, half-maximal cytotoxic concentration: 112000 nM
The estimate for compound 4 lay 2.0-fold (0.30 log units) above the measured number; the measured number falls inside the stated range.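

Among the compounds shown here, replacing 4-sulfamoylpiperazin-1-yl with 3-(methanesulfonamido)piperidin-1-yl on an aromatic carbon para to a large group gives the first readable step for this change on the core of compound 1 in this assay: an at least 1.9-fold lower number from compound 1 to compound 4 (0.29 log units; that floor lies within the scatter). As far as these compounds go, the true size of this step stays open because compound 1 is reported as a limit and not as a number: the limit of > 222000 nM in this assay, at which 1 of the 4 values shown sits. Compound 4 also gives the 3-(methanesulfonamido)piperidin-1-yl group a measured number on this core, whereas on the core of compound 2 the same group stands only as a limit: the limit of > 217000 nM in this assay, at which 1 of the 4 values shown sits.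

The compounds shown leave open whether the read-out follows the six-membered ring or the group attached to it, as the change from compound 1 to compound 4 alters both at once. A piperidin-1-yl ring carrying an amine or a carboxylic acid in place of the methanesulfonamido group, or a longer chain between the ring and the sulfonyl group, would be needed on this core to tell these two parts apart.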